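Taking the cyclohexyl off compound 2

This account rests on a few compounds, and the source may have more. Where it says the series, first, only, none or still open, it means among the compounds named here.

In an ADME assay on BHK-21 cells (Mesocricetus auratus) for cytotoxicity, read by MTT assay (a lower number here means that less compound is tolerated, a higher number that more compound is tolerated), compound 2 (`C/C(=N\NC(N)=S)c1ccc2c(c1)nc(-c1ccoc1)n2C1CCCCC1`) reads > 100000 nM, which is a limit of the assay and not a number. Compound 1 (`C/C(=N\NC(N)=O)c1ccc2[nH]c(-c3ccoc3)nc2c1`) reads > 100000 nM, also a limit. Going by the values given here, neither compound gives an exact figure, and no measured step between compounds exists to show how large a structural change might be here.

Compound 3 (`C/C(=N\NC(N)=S)c1ccc2[nH]c(-c3ccoc3)nc2c1`) has not yet been measured. It carries hydrogen in place of cyclohexyl on an aromatic nitrogen, (hydrogen in place of cyclohexyl on an aromatic nitrogen).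

With only limits to go on, the expectation in this assay is for a small change at most: either none beyond the scatter or a modest move towards less compound being tolerated. The estimated change is an at least 1.2-fold lower number from compound 2 to compound 3 (0.09 log units; that floor lies within the scatter). A further limit is also quite possible. For compound 3 the estimated value is 80000 nM, with an expected range from 25000 nM to 100000 nM.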

Compound 3, half-maximal cytotoxic concentration: > 100000 nM
Compound 3: only a limit was reported (the forecaster's own chance of this, stated with the estimate: 65%); at least 1.2-fold (0.09 log units) between middle value and limit.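

Compound 3 gives only a limit, as do compound 1 and compound 2, so the steps to compound 3 from compound 1 and from compound 2 cannot be read: the limit of > 100000 nM in this assay, at which 3 of the 3 values shown sit. Going by these compounds, the concentration at which any of these three compounds becomes toxic to the cells remains open, as does whether swapping cyclohexyl for hydrogen changes it.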